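From cyclopentyl to 2-methoxyethyl on the shared core

The compounds below may be only part of what the source reports. "The series", "measured", "known", "first", "only" and "open" are said of these compounds alone.

In an ADME assay on microsomes from liver (Homo sapiens) for metabolic stability, read by mass spectrometry, using NADPH, with a stated time of 10 min (on this read-out higher numbers stand for a more stable compound and lower numbers for a less stable compound), compound 3 (`COc1cccc(OC)c1-c1c(C2CCCC2)[nH]c(=O)c(-c2nnc(Cc3ccc(Cl)cc3)o2)c1O`) gives 80% as its reading. That reading lies within the scatter of compound 2 (`CCCCc1[nH]c(=O)c(-c2nnc(Cc3ccccc3)o2)c(O)c1-c1c(OC)cccc1OC`) at 87%. Compound 1 (`CCCCc1[nH]c(=O)c(-c2n[nH]c(Cc3ccccc3)n2)c(O)c1-c1c(OC)cccc1OC`) reads 36% on the same scale. The gap between compound 1 and compound 3 lies beyond the scatter.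

Compound 4 (`COCCc1[nH]c(=O)c(-c2nnc(Cc3ccc(Cl)cc3)o2)c(O)c1-c1c(OC)cccc1OC`) carries 2-methoxyethyl in place of cyclopentyl on an aromatic carbon, next to the ring nitrogen and ortho to a 2,6-dimethoxyphenyl group (2-methoxyethyl in place of cyclopentyl on an aromatic carbon).

Going by the values given here, no two measured compounds differ at this place alone, so the series offers no direct measure of this change. Compound 2 and compound 3 differ in more than one place, and their two values still fall within the scatter of each other. Compound 1 shows that a much lower reading does occur in the series, although it also differs from compound 3 in more than one place.

A modest fall is expected in this assay and the estimated step is a number 10 percentage points lower from compound 3 to compound 4 (within the scatter) at about the edge of the scatter. For compound 4 the expected value is 70% within an estimated range of 50% to 88% for repeat measurements.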

Compound 4, percent of the compound remaining: 86%
Estimate against measurement, compound 4: 16 percentage points below; the measured number falls inside the stated range.
By their numbers in this assay, from the lowest: compound 1; then compounds 3, 4 and 2 (each within the scatter of the next).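

The exchange of cyclopentyl for 2-methoxyethyl gives the series its first direct step at this position, on an aromatic carbon next to the ring nitrogen and ortho to a 2,6-dimethoxyphenyl group: in this assay the step is a number 6 percentage points higher from compound 3 to compound 4 (within the scatter). Going by these compounds alone, for this pair, then, a chain with no ring and one hydrogen-bond acceptor can stand in place of a five-membered ring of carbon only without moving the reading beyond the scatter, so the low reading of compound 1 has no counterpart in this change. No measurement at hand accounts for this outcome or assigns any part of it to either group.

This is a single step on a single pair, so it leaves open whether the same exchange would hold with other substituents elsewhere on the shared core. It also leaves open how far this position tolerates groups of another kind, such as a longer chain ending in an amine or a carboxylic acid, and whether any of these would move the reading beyond the scatter.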